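This account rests on a few compounds, and the source may have more. Where it says the series, first, only, none or still open, it means among the compounds named here.

Working notes on the series. All four compounds share one core and differ only in the group on the carbon with a double bond to nitrogen. Compound 1 `CN(C)CCn1cnnc1-c1cc(Oc2ccc(NC(=O)N/N=C/c3c[nH]c4ccccc34)cc2F)ccn1` carries 1H-indol-3-yl there, and in a functional assay on A549 cells (Homo sapiens) for cytotoxicity, read by MTT assay, with a stated time of 72 h (on this read-out lower numbers stand for stronger inhibition and higher numbers for weaker inhibition), compound 1 gives 820 nM. Compound 2 `CN(C)CCn1cnnc1-c1cc(Oc2ccc(NC(=O)N/N=C/c3ccccc3)cc2F)ccn1` has phenyl in that place, and in this assay compound 2 gives 1860 nM; the step is a 2.3-fold higher number from compound 1 to compound 2 (0.36 log units; beyond the scatter). Compound 3 `CN(C)CCn1cnnc1-c1cc(Oc2ccc(NC(=O)N/N=C/c3ccc(O)c(O)c3)cc2F)ccn1` carries 3,4-dihydroxyphenyl. For compound 3 this assay returns only a limit, > 100000 nM, not a number. The steps to it are an at least 120-fold higher number from compound 1 to compound 3 (2.08 log units; beyond the scatter) and an at least 53-fold higher number from compound 2 to compound 3 (1.73 log units; beyond the scatter), so compound 3 stands apart from the other two at the weak end of the numbers shown, because of the limit of > 100000 nM in this assay, at which 1 of the 3 values shown sits.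

Compound 4 `CN(C)CCn1cnnc1-c1cc(Oc2ccc(NC(=O)N/N=C/c3ccc(O)cc3)cc2F)ccn1` differs from compound 3 by hydrogen in place of hydroxy on an aromatic carbon, the change reading 3,4-dihydroxyphenyl to 4-hydroxyphenyl. The step that bears on it most directly is an at least 53-fold higher number from compound 2 to compound 3 (1.73 log units; beyond the scatter), which put 3,4-dihydroxyphenyl in place of phenyl; compound 4 undoes part of that change, so a move back toward the number of compound 2 is expected, though only part of the way, and a repeat of the limit cannot be ruled out. The expected step is an at least 12-fold lower number from compound 3 to compound 4 (1.09 log units; beyond the scatter). In this assay compound 4 is expected near 8000 nM, within 1500 nM to 100000 nM.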

Compound 4, half-maximal inhibitory concentration: 3560 nM
The estimate for compound 4 lay 2.2-fold (0.35 log units) above the measured number, within the range that was stated.
By their numbers in this assay, from the lowest: compound 1; then compounds 2 and 4 (each within the scatter of the next). At a limit, above all of these: compound 3.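

At this position, hydrogen in place of the hydroxy ortho to a hydroxy group gives an at least 28-fold lower number from compound 3 to compound 4 (1.44 log units; beyond the scatter) in this assay, a bound rather than a size because compound 3 stands at a limit and not at a number: the limit of > 100000 nM in this assay, at which 1 of the 4 values shown sits. The 4-hydroxyphenyl and phenyl groups are not separated here, a 1.9-fold higher number from compound 2 to compound 4 (0.28 log units; within the scatter), so among these compounds a single hydroxy does not bring the loss seen with 3,4-dihydroxyphenyl, and that loss appears only with the second hydroxy. The 1H-indol-3-yl group of compound 1 remains apart from 4-hydroxyphenyl, a 4.3-fold higher number from compound 1 to compound 4 (0.64 log units; beyond the scatter), so the step from the indole is a real one for this hydroxylated ring as well, and the hydroxy-free phenyl ring is not the only six-membered ring that keeps a measurable number.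

The compounds shown leave open how far past its limit compound 3 really lies. They also leave open whether the loss follows the free hydroxy pair itself, which a methoxy group or an amine in place of either hydroxy on the same ring would test.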